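A few compounds are considered here, and "the series" means these few. Any claim that something is new, unique, unknown or untested is made for them only; others in the source may bear on it.

Compound 2 `O=C(CSC(=S)N[C@H]1CCOC1=O)Nc1ccc(F)cc1` gives the lowest number of the two compounds measured in a functional assay on MCF7 cells (Homo sapiens) for cytotoxicity, read by MTT assay, with a stated time of 72 h (a lower number here means a stronger inhibitor, a higher number a weaker inhibitor), at 5830 nM. For the measured compounds named here, its only neighbour, compound 1 `O=C(CSC(=S)N[C@H]1CCOC1=O)Nc1ccc(Cl)cc1`, gives 50300 nM in this assay. Going by the values given here, the one recorded step, an 8.6-fold lower number from compound 1 to compound 2 (0.94 log units; beyond the scatter), joins them. Compound 3 `CC(=O)c1ccc(NC(=O)CSC(=S)N[C@H]2CCOC2=O)cc1` differs from compound 2 by acetyl in place of fluoro on an aromatic carbon. Among the compounds with values here, no measured step concerns an acetyl group, so the only guide is that halogen step, which shows that a change at this position can move the number by a modest but clear amount. Because of the size of an 8.6-fold lower number from compound 1 to compound 2 (0.94 log units; beyond the scatter) a shift of similar size in either direction is plausible for compound 3, and with no direction to lean on the expected value sits somewhat above that of compound 2. Compound 3 is therefore estimated at 12000 nM in this assay, within a range from 2500 nM to 60000 nM, which is expected to mean a 2.1-fold higher number from compound 2 to compound 3 (0.31 log units; beyond the scatter).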

Compound 3, half-maximal inhibitory concentration: > 128000 nM
Compound 3: no number, only a limit; the forecaster's own chance of this, stated with the estimate: 15%; middle value at least 10-fold (1.02 log units) from the limit.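

In this assay compound 3 gives no number, only a limit: the limit of > 128000 nM in this assay, at which 1 of the 3 values shown sits.

Even so, the swap on this aromatic carbon, para to a large group, can be read as a lower bound, with an at least 21-fold higher number from compound 2 to compound 3 (1.34 log units; beyond the scatter). Acetyl also goes past the weaker of the two halogen compounds, with an at least 2.5-fold higher number from compound 1 to compound 3 (0.40 log units; beyond the scatter), so the three groups now spread in a clear order, and this position can lose far more cytotoxic effect than the halogen pair alone suggested.

On these data alone, how far compound 3 really lies beyond its limit stays unknown, and three groups cannot separate the effect of acetyl's size from that of its carbonyl. A plain hydrogen, a methoxy group, an amine or a carboxylic acid at this position would show whether fluoro is a rare good fit or one of many.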